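Amide substituent series: step from compound 2 to compound 3

The compounds below may be only part of what the source reports. "The series", "measured", "known", "first", "only" and "open" are said of these compounds alone.

Measured compounds:
compound 1, `O=C(Nc1cc(Oc2ccc(Nc3nccc4[nH]cc(-c5ccc(F)cc5)c(=O)c34)cc2F)ccn1)C1CCC1`: 46%
compound 2, `O=C(CO)Nc1cc(Oc2ccc(Nc3nccc4[nH]cc(-c5ccc(F)cc5)c(=O)c34)cc2F)ccn1`: 18.5%

In a functional assay on HT-29 cells (Homo sapiens) for antiproliferative activity, read by MTT assay, with a stated time of 72 h, tested at 10 uM (on this read-out higher numbers stand for more inhibition at the one concentration tested (going by the name of the read-out) and lower numbers for less inhibition), compound 1 gives 46%, and compound 2 gives 18.5%. Among the measured compounds shown here, compound 2 stands lowest of the two numbers; the only step measured, a number 27.5 percentage points lower from compound 1 to compound 2 (beyond the scatter), separates it from compound 1.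

Compound 3, `CC(C)(O)C(=O)Nc1cc(Oc2ccc(Nc3nccc4[nH]cc(-c5ccc(F)cc5)c(=O)c34)cc2F)ccn1`, is not yet measured. It differs from compound 2 in one place: 1-hydroxy-1-methylethyl in place of hydroxymethyl on a carbonyl carbon. For the measured compounds named here, the one step that bears on this change is the one from compound 1 to compound 2, where a cyclobutyl gave way to a hydroxymethyl on the same carbonyl carbon and the number fell by a number 27.5 percentage points lower from compound 1 to compound 2 (beyond the scatter). Compound 3 keeps the hydroxyl of compound 2 while adding carbon atoms toward the size of compound 1, so a modest rise from compound 2 is expected, though the direction rests on a single step. The step from compound 2 to compound 3 is estimated as a number 9.5 percentage points higher from compound 2 to compound 3 (within the scatter). For compound 3 the expected value is 28%, within 10% to 46%.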

Compound 3, a percentage reported as inhibition, at one concentration (the size of the read-out at that concentration, not a potency): -2.9%
The estimate for compound 3 lay 30.9 percentage points above the measured number; the whole stated range lies above it.
By their numbers in this assay, from the lowest: compound 3; then compound 2; then compound 1.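

Within this assay, the added carbon on the hydroxyl-bearing group on the carbonyl carbon does not bring the number back toward that of compound 1: 1-hydroxy-1-methylethyl in place of hydroxymethyl gives a number 21.4 percentage points lower from compound 2 to compound 3 (beyond the scatter) and extends the fall already seen at this position. Set directly against cyclobutyl, the same group gives a number 48.9 percentage points lower from compound 1 to compound 3 (beyond the scatter) and leaves both hydroxyl-bearing groups below cyclobutyl, so among these three compounds a larger group on the carbonyl carbon does not by itself mean a higher number. No evidence is available on why the number falls at this position. Open, as far as these compounds go, is whether the hydroxyl or the two added methyl groups drive the loss. A methoxymethyl, an aminomethyl or an unbranched hydroxyethyl chain on the same carbonyl carbon would help separate the two.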